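The compounds below may be only part of what the source reports. "The series", "measured", "known", "first", "only" and "open" are said of these compounds alone.

Working notes on the series.

Compound 2 `C1=C(c2cccnc2)C[C@H]2CNC[C@@H]1C2` gives 37 nM in an in vitro functional assay on SH-SY5Y cells for agonist activity at Neuronal acetylcholine receptor; alpha3/beta4 (Homo sapiens), read by FLIPR and calcium flux; a lower number here means that less compound is needed, a higher number that more compound is needed for the effect. Compound 1 `CN1C[C@H]2C=C(c3cccnc3)C[C@H](C2)C1` carries methyl in place of hydrogen on an amine nitrogen in a ring and, in this assay, compound 1 gives 7530 nM; the step of a 200-fold higher number from compound 2 to compound 1 (2.31 log units; beyond the scatter) is large and beyond the scatter.

Compound 3 `CC(C)Oc1cncc(C2=CC3CNCC(C2)C3)c1` has a different core from compound 2; how the two cores differ is not broken down here. In this assay compound 3 gives 69 nM, which stands within the scatter of the number for compound 2 and far from the number for compound 1.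

Compound 4 `CC(C)Oc1cncc(C2=CC3CC(C2)CN(C)C3)c1` is not yet measured. Among the measured compounds shown here, it carries methyl in place of hydrogen on an amine nitrogen in a ring, the same change as the one from compound 2 to compound 1, with the place described in the same words. For the measured compounds named here, the only precedent is the step from compound 2 to compound 1, so a step of similar direction and size is expected from compound 3 to compound 4, namely a 140-fold higher number from compound 3 to compound 4 (2.16 log units; beyond the scatter); this rests on a single pair and no other instance of the change is available. Compound 4 is therefore estimated at 10000 nM, with a plausible range from 3000 nM to 40000 nM.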

Compound 4, half-maximal effective concentration: > 10000 nM
Compound 4 ended at the assay's limit (the forecaster's own chance of this, stated with the estimate: 20%); the middle value lies on the limit itself.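

In this assay, methyl in place of hydrogen on an amine nitrogen in a ring gives a large step on the second core as well, an at least 140-fold higher number from compound 3 to compound 4 (2.16 log units; beyond the scatter), so the direction of the change carries over from the core of compound 2 to the core of compound 3: the same change on two cores in this assay, a 200-fold higher number (2.31 log units; beyond the scatter) from compound 2 to compound 1 and an at least 140-fold higher number (2.16 log units; beyond the scatter) from compound 3 to compound 4; the limit leaves it open whether they differ. Compound 4 stands at a limit of the assay and not at a number: the limit of > 10000 nM in this assay, at which 1 of the 4 values shown sits. The full size of the step on this core therefore stays unknown, and with only two cores shown, nothing follows for any other core.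

The compounds shown leave open how a group larger than methyl on the same amine nitrogen, such as ethyl or a longer chain, would read in this assay. Also open, on these data alone, is whether the change would give a step of the same direction on a core carrying a further group such as an amine or a carboxylic acid.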